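The compounds below may be only part of what the source reports. "The series", "measured", "known", "first", "only" and "open" are said of these compounds alone.

Compound 1 `Nc1nc(C(F)(F)F)cc2c1[nH]c(=O)n2Cc1ccc(NCc2ccccc2)nc1` — in an in vitro ADME assay on microsomes from liver (Rattus norvegicus) for pharmacokinetics (on this read-out lower numbers stand for slow clearance and higher numbers for fast clearance), compound 1 gives 16 mL.min-1.g-1.
Compound 2 `CN(CCN1CCCCC1)c1ccc(Cn2c(=O)[nH]c3c(N)nc(C(F)(F)F)cc32)cn1` — in this assay compound 2 gives 13 mL.min-1.g-1.
Compound 3 `CN(C)CCNc1ccc(Cn2c(=O)[nH]c3c(N)nc(C(F)(F)F)cc32)cn1` — in this assay compound 3 gives 16 mL.min-1.g-1.

Compound 3 stands level with compound 1: no change at the digits printed from compound 1 to compound 3 (within the scatter). Against compound 2 the difference is a 1.2-fold higher number from compound 2 to compound 3 (0.09 log units; within the scatter), so all three numbers sit within the scatter of one another.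

Compound 4 `CN1CCN(CCN(C)c2ccc(Cn3c(=O)[nH]c4c(N)nc(C(F)(F)F)cc43)cn2)CC1` differs from compound 3 in one place: methyl(2-(4-methylpiperazin-1-yl)ethyl)amino in place of (2-(dimethylamino)ethyl)amino on an aromatic carbon. Among the measured compounds shown here, the step that bears most directly on this change is the one between compound 2 and compound 3, where the same kind of swap between a methylated amino carrying a six-membered saturated ring and an open (2-(dimethylamino)ethyl)amino gave a 1.2-fold higher number from compound 2 to compound 3 (0.09 log units; within the scatter). The step of a 1.2-fold lower number from compound 1 to compound 2 (0.09 log units; within the scatter), which also brought in a methyl(2-(piperidin-1-yl)ethyl)amino, likewise stayed within the scatter. On this basis no step beyond the scatter is expected in this assay for compound 4, and the change is estimated at a 1.2-fold lower number from compound 3 to compound 4 (0.09 log units; within the scatter). Compound 4 is therefore expected to give about 13 mL.min-1.g-1, with a range from 7 mL.min-1.g-1 to 26 mL.min-1.g-1.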

Compound 4, intrinsic clearance in microsomes: 15 mL.min-1.g-1
Compound 4: the middle estimate sits 1.2-fold (0.06 log units) below what was measured, and the stated range covers the measured number.
By their numbers in this assay, from the lowest: compounds 2, 4, 1 and 3 (each within the scatter of the next).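

In this assay, the larger methyl(2-(4-methylpiperazin-1-yl)ethyl)amino group on this aromatic carbon stays within the scatter of the open (2-(dimethylamino)ethyl)amino group (a 1.1-fold lower number from compound 3 to compound 4 (0.03 log units; within the scatter)) and of benzylamino (a 1.1-fold lower number from compound 1 to compound 4 (0.03 log units; within the scatter)). Among the compounds shown here, the new compound also gives the first comparison of the two saturated rings at the chain end: 4-methylpiperazin-1-yl in place of piperidin-1-yl again stays within the scatter (a 1.2-fold higher number from compound 2 to compound 4 (0.06 log units; within the scatter)). The second ring nitrogen, the extra heavy atoms and the loss of the hydrogen-bond donor therefore do not separate these compounds on this read-out.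

On these data alone, whether a morpholin-4-yl group at the chain end, a carboxylic acid or a longer chain would also stay within the scatter remains open. Nothing available explains why these four numbers lie so close together.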